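Methoxy in place of trifluoromethyl on the benzyl ring

This account rests on a few compounds, and the source may have more. Where it says the series, first, only, none or still open, it means among the compounds named here.

The shared core is varied only at one aromatic carbon of the benzyl ring. In a functional assay on HeLa cells (Homo sapiens) for antiproliferative activity, read by sulforhodamine B assay, with a stated time of 48 h (a higher number here means a weaker inhibitor of growth, a lower number a stronger inhibitor of growth), compound 1 `COc1ccc(-c2nn(-c3ccccc3)cc2C(=O)NCc2cn(Cc3ccc(F)cc3)nn2)cc1` gives 500 nM, compound 2 `COc1ccc(-c2nn(-c3ccccc3)cc2C(=O)NCc2cn(Cc3ccc(Cl)cc3)nn2)cc1` gives 6400 nM, and compound 3 `COc1ccc(-c2nn(-c3ccccc3)cc2C(=O)NCc2cn(Cc3ccc(C(F)(F)F)cc3)nn2)cc1` gives 6200 nM. Compound 3 thus stands second highest of the three numbers; its nearest neighbour is compound 2 and the two lie within the scatter, while the step of a 12-fold higher number from compound 1 to compound 3 (1.09 log units; beyond the scatter) is large, as is a 13-fold higher number from compound 1 to compound 2 (1.11 log units; beyond the scatter); the step of a 1.0-fold lower number from compound 2 to compound 3 (0.01 log units; within the scatter) is within the scatter. Compound 4 `COc1ccc(Cn2cc(CNC(=O)c3cn(-c4ccccc4)nc3-c3ccc(OC)cc3)nn2)cc1` differs from compound 3 by methoxy in place of trifluoromethyl on an aromatic carbon, on an aromatic carbon of a six-membered aromatic ring of carbon only, para to a large group. Within the data shown here, no measured step introduces a methoxy at this place, so the measured steps bear on it only indirectly: they show that a change at this carbon can move this assay by a large amount or not at all. Among the measured compounds shown here, with no direct precedent, compound 4 is expected to land between the extremes seen, an estimated 2.1-fold lower number from compound 3 to compound 4 (0.32 log units; beyond the scatter) from compound 3, giving compound 4 an expected 3000 nM with a range of 600 nM to 15000 nM.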

Compound 4, concentration for 50% growth inhibition: 450 nM
Compound 4: the middle estimate sits 6.7-fold (0.82 log units) above what was measured; measured number outside the range, below it.
By their numbers in this assay, from the lowest: compounds 4 and 1 (each within the scatter of the next); then compounds 3 and 2 (each within the scatter of the next).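

In this assay, the methoxy result shows that the large loss seen with chloro and trifluoromethyl does not follow from every replacement of fluoro at this aromatic carbon: a 1.1-fold lower number from compound 1 to compound 4 (0.05 log units; within the scatter) leaves methoxy level with fluoro, whereas a 14-fold lower number from compound 3 to compound 4 (1.14 log units; beyond the scatter) and a 14-fold lower number from compound 2 to compound 4 (1.15 log units; beyond the scatter) are both large. The four compounds therefore fall into two sets at this one carbon, fluoro with methoxy and chloro with trifluoromethyl, whereas fluoro alone stood apart among the earlier three. Nothing available explains this split.

The compounds shown leave open how a hydroxyl, an amine or a longer chain such as ethoxy would behave at this carbon. They also leave open whether the same two sets would appear in cell lines other than HeLa.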